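Swapping a halogenated ring for a methoxyphenyl on a thiourea

A few compounds are considered here, and "the series" means these few. Any claim that something is new, unique, unknown or untested is made for them only; others in the source may bear on it.

Three compounds share one core and differ only in the aryl group on the thiourea. In a functional assay on HCT-116 cells (Homo sapiens) for antiproliferative activity, read by MTT assay (a higher number here means a weaker inhibitor, a lower number a stronger inhibitor), compound 1 `CNC(=O)c1ccc(Oc2cccc(NC(=S)Nc3ccc(OC(F)(F)F)cc3)c2)nc1` gives 54700 nM, compound 2 `CNC(=O)c1ccc(Oc2cccc(NC(=S)Nc3ccc(F)c(F)c3)c2)nc1` gives 38200 nM, and compound 3 `CNC(=O)c1ccc(Oc2cccc(NC(=S)Nc3ccc(F)c(Cl)c3)c2)nc1` gives 25400 nM. Compound 3 has the lowest number of the three: the gap to compound 2 is within the scatter, and only compound 1 lies beyond it. Among the compounds with values here, the one single-point step, a 1.5-fold lower number from compound 2 to compound 3 (0.18 log units; within the scatter), is itself within the scatter. Compound 4 `CNC(=O)c1ccc(Oc2cccc(NC(=S)Nc3ccc(OC)cc3)c2)nc1` differs from compound 3 as follows: 4-methoxyphenyl in place of 3-chloro-4-fluorophenyl on an amide-type nitrogen. Within the data shown here, no measured step covers this change; all three are weak, and compound 1, which also carries an oxygen-linked group, shows the highest number. A modest rise is therefore expected, as a 1.8-fold higher number from compound 3 to compound 4 (0.25 log units; within the scatter). Compound 4 is estimated at 45000 nM, likely between 15000 nM and 140000 nM.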

Compound 4, half-maximal inhibitory concentration: 49800 nM
Beside the measured number, compound 4's estimate is 1.1-fold (0.04 log units) below it; low and high end bracket the measured number.
By their numbers in this assay, from the lowest: compounds 3, 2, 4 and 1 (each within the scatter of the next, the first and the last beyond it).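

In this assay, 4-methoxyphenyl in place of a halogenated ring on the amide-type nitrogen gives a 2.0-fold higher number from compound 3 to compound 4 (0.29 log units; within the scatter) and a 1.3-fold higher number from compound 2 to compound 4 (0.12 log units; within the scatter); these readings do not separate it from either halogenated ring. With methyl in place of trifluoromethyl on the oxygen, the result is a 1.1-fold lower number from compound 1 to compound 4 (0.04 log units; within the scatter); the two oxygen-linked groups cannot be told apart here either. No measurement is available that would explain these numbers. Still open, as far as these compounds go, is whether an amine or a carboxylic acid on the aromatic ring, or a longer chain on the oxygen, would give a step beyond the scatter.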